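The compounds below may be only part of what the source reports. "The series", "measured", "known", "first", "only" and "open" are said of these compounds alone.

In a functional assay on J774.A1 cells (Mus musculus) for inhibition, read by immunoassay, with a stated time of 12 h, tested at 30 uM (on this read-out higher numbers stand for more inhibition at the one concentration tested (going by the name of the read-out) and lower numbers for less inhibition), compound 3 `C=CCOc1ccccc1C1CC(=O)c2ccccc2O1` gives 47%, the second highest of the three numbers. Compound 1 `O=C1CC(c2ccccc2OCc2ccc(F)cc2)Oc2ccccc21` gives 42.1%, and the two lie within the scatter of each other, with a number 4.9 percentage points higher from compound 1 to compound 3 (within the scatter). Compound 2 `CC(C)c1ccc(COc2ccccc2C2CC(=O)c3ccccc3O2)cc1` gives 91.7%, and the drop a number 44.7 percentage points lower from compound 2 to compound 3 (beyond the scatter) is a large one. Compound 4 `CCCCCOc1ccccc1C1CC(=O)c2ccccc2O1` differs from compound 3 as butyl in place of vinyl on a saturated chain carbon bound to an oxygen on an aromatic ring. Both measured steps at this chain carbon bear on it: a number 4.9 percentage points higher from compound 1 to compound 3 (within the scatter) stayed within the scatter, whereas a number 44.7 percentage points lower from compound 2 to compound 3 (beyond the scatter) shows that the group on this carbon can move the read-out strongly. Butyl is a chain rather than an aryl group like 4-isopropylphenyl, so only a modest rise is expected, a number 8 percentage points higher from compound 3 to compound 4 (within the scatter). Compound 4 is therefore estimated at 55%, within 35% to 78%.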

Compound 4, a percentage reported as inhibition, at one concentration (the size of the read-out at that concentration, not a potency): 40.1%
The estimate for compound 4 lay 14.9 percentage points above the measured number; low and high end bracket the measured number.
By their numbers in this assay, from the lowest: compounds 4, 1 and 3 (each within the scatter of the next); then compound 2.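

Butyl in place of vinyl on this saturated chain carbon gives a number 6.9 percentage points lower from compound 3 to compound 4 (within the scatter), and butyl in place of 4-fluorophenyl gives a number 2 percentage points lower from compound 1 to compound 4 (within the scatter), so in this assay a saturated chain, an unsaturated chain and a fluorinated aryl group cannot be told apart here. Only 4-isopropylphenyl stands apart, with a number 51.6 percentage points lower from compound 2 to compound 4 (beyond the scatter), so a simple swap between chain and aryl does not decide the read-out. No measured evidence accounts for this. Going by these compounds, whether a longer chain such as octyl, or a chain ending in an amine, reaches the number of compound 2 stays open.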